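Furan-2-yl in Place of Phenyl: An Expected Step

The source may report more compounds than this note shows. Statements on the series, on what has been measured and on what is new or still open speak of the compounds shown alone.

Compound 1 `COc1ccc(C2=C(c3ccccc3)C(=O)N3CCCC3C2)cc1`: 390 nM
Compound 2 `COc1ccc(C2=C(c3ccsc3)C(=O)N3CCCC3C2)cc1`: 1500 nM
Compound 3 `CSc1ccc(C2=C(c3ccccc3)C(=O)N3CCCC3C2)cc1`: 1000 nM

Of the compounds shown here, three sharing one core have been measured in a functional assay on HCT-116 cells (Homo sapiens) for cytotoxicity; a higher number here means a weaker inhibitor, a lower number a stronger inhibitor. Compound 3 stands second highest of the three numbers; compound 2 sits within the scatter of it, while compound 1 gives a clearly lower number. Compound 4 `CSc1ccc(C2=C(c3ccco3)C(=O)N3CCCC3C2)cc1` has not yet been measured. It differs from compound 3 in one place: furan-2-yl in place of phenyl on a double-bonded ring carbon.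

Among the compounds with values here, no measured step exchanges phenyl for furan-2-yl. The nearest guide is the exchange of phenyl for another five-membered aromatic ring with one hetero atom: a 3.8-fold higher number from compound 1 to compound 2 (0.59 log units; beyond the scatter), a modest weakening. The exchange of methoxy for methylsulfanyl, a 2.6-fold higher number from compound 1 to compound 3 (0.41 log units; beyond the scatter), is already built into compound 3 and does not bear on the new change. A weakening of similar size is therefore expected, though furan-2-yl and thiophen-3-yl are different rings and a single example is a thin basis, so the range is kept wide. Compound 4 is expected to give 2500 nM in this assay, between 1000 nM and 6500 nM. That would correspond to an expected 2.5-fold higher number from compound 3 to compound 4 (0.40 log units; beyond the scatter).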

Compound 4, half-maximal inhibitory concentration: 3000 nM
For compound 4 the middle estimate is 1.2-fold (0.08 log units) below the measured one; the measured number falls inside the stated range.
By their numbers in this assay, from the lowest: compound 1; then compounds 3, 2 and 4 (each within the scatter of the next, the first and the last beyond it).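

In this assay, furan-2-yl in place of phenyl on the double-bonded ring carbon gives a 3.0-fold higher number from compound 3 to compound 4 (0.48 log units; beyond the scatter), so this is a second exchange at this carbon that moves the number beyond the scatter and towards weaker inhibition. Alongside a 3.8-fold higher number from compound 1 to compound 2 (0.59 log units; beyond the scatter), seen with thiophen-3-yl, it shows that both replacements of phenyl by a five-membered aromatic ring with one hetero atom raise the number, with methoxy on the other aromatic ring in one case and methylsulfanyl in the other, and none of the compounds shown goes against this. Furan-2-yl has one hydrogen-bond acceptor and phenyl none, and it also has fewer heavy atoms, but no measurement shown here ties the rise to either difference or to anything else.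

Within the data shown here, still open is whether furan-2-yl gives a step of similar size with methoxy in place of methylsulfanyl, since each ring exchange has been read against only one partner group. Also open, on these data alone, is how this carbon responds to a six-membered replacement, such as pyridin-3-yl or 4-fluorophenyl, rather than a five-membered ring.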